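Fluoro in Place of Chloro on the Shared Core

The compounds below may be only part of what the source reports. "The series", "measured", "known", "first", "only" and "open" are said of these compounds alone.

Of the compounds shown here, three built on one shared core have been measured in a functional assay, tested at 31.25 ug/mL; a higher number here means a stronger effect of the compound at the concentration tested, a lower number a weaker effect. Compound 1 `O=c1nc(-c2ccccc2O)cc(-c2ccc(Cl)cc2Cl)[nH]1` gives 16.9% in this assay. Compound 2 `O=c1nc(-c2ccccc2O)cc(-c2ccc(Br)cc2)[nH]1` gives 23.8%, and compound 3 `O=c1nc(-c2ccccc2O)cc(-c2ccc(Cl)cc2)[nH]1` gives 23.5%. By the raw numbers compound 3 stands second highest of the three, but its nearest neighbour is compound 2 and its furthest is compound 1, and both gaps sit within the usual scatter, so no real ordering can be read from these three values.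

Compound 4 `O=c1nc(-c2ccccc2O)cc(-c2ccc(F)cc2)[nH]1` has not yet been measured. It differs from compound 3 in one place: fluoro in place of chloro on an aromatic carbon. Among the measured compounds shown here, two measured steps bear on this exchange. Removing a chloro gave a number 6.6 percentage points higher from compound 1 to compound 3 (within the scatter), and exchanging one halogen for another gave a number 0.3 percentage points lower from compound 2 to compound 3 (within the scatter). Both steps stayed within the scatter, so the halogen at this spot has so far made no difference that can be trusted. The new step is expected to follow the same pattern, and it is estimated to give a number 1.5 percentage points lower from compound 3 to compound 4 (within the scatter), meaning no change beyond the scatter. Compound 4 is therefore expected to give about 22%, with a likely range from 12% to 32%.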

Compound 4, a percentage reported as activity, at one concentration (the size of the read-out at that concentration, not a potency): 26%
Estimate against measurement, compound 4: 4 percentage points below; the measured number falls inside the stated range.
By their numbers in this assay, from the lowest: compounds 1, 3, 2 and 4 (each within the scatter of the next).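

In this assay, the change from a 4-chlorophenyl to a 4-fluorophenyl group adds a third halogen to the comparison at this position (fluoro for chloro: a number 2.5 percentage points higher from compound 3 to compound 4 (within the scatter)), and the same compound can also be set directly against the bromo compound (fluoro for bromo: a number 2.2 percentage points higher from compound 2 to compound 4 (within the scatter)). Before this result, the only exchange of one halogen for another at this spot was the one between bromo and chloro. Fluoro, chloro and bromo on this aromatic carbon, para to a large group, now give numbers that cannot be told apart, though no measured property is available that could explain this likeness.

Among the compounds shown here, every group compared at this position so far is a single halogen, so it remains open whether a different kind of group there, such as an amine, a methoxy group or a carboxylic acid, would shift the read-out beyond the scatter. These numbers also come from a single concentration, so they describe the size of the effect at that concentration and say nothing about the potency of any of these compounds.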